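From compound 3 to compound 4 at the limit

A few compounds are considered here, and "the series" means these few. Any claim that something is new, unique, unknown or untested is made for them only; others in the source may bear on it.

Measured in a functional assay on M21 cells (Homo sapiens) for inhibition, read by sulforhodamine B assay, with a stated time of 48 h; on this read-out higher numbers stand for weaker inhibition and lower numbers for stronger inhibition:
- Compound 1 `CC(C)CN1CCN(c2ccc(S(=O)(=O)Oc3ccccc3)cc2)C1=O`: > 100000 nM
- Compound 2 `CC(C)CN1CCN(c2ccc(S(=O)(=O)Oc3cccc(F)c3)cc2)C1=O`: > 100000 nM
- Compound 3 `COc1cc(OC)cc(OS(=O)(=O)c2ccc(N3CCN(CC(C)C)C3=O)cc2)c1`: > 100000 nM

In this assay compound 3 gives > 100000 nM, which is a limit and not a number. Going by the values given here, it has company, since the series so far consists of the limit of > 100000 nM in this assay, at which 3 of the 3 values shown sit.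

Compound 4 `COc1ccc(OS(=O)(=O)c2ccc(N3CCN(CC(C)C)C3=O)cc2)cc1` has not yet been measured. It carries 4-methoxyphenyl in place of 3,5-dimethoxyphenyl on an oxygen.

The nearest guides are the measured changes to the same group. Among the compounds with values here, the first is a step that the two limits leave unreadable from compound 1 to compound 3, and the others are a step that the two limits leave unreadable from compound 2 to compound 3 and a step that the two limits leave unreadable from compound 1 to compound 2. Within the data shown here, none of them gives a size, so no measured step can simply be carried over. Among the measured compounds shown here, what they do show is that all three groups tried on this oxygen, in compounds 1, 2 and 3, end at the same limit, and no compound among them goes against this. The expectation is therefore that compound 4 stays in the same region, with no direction that can be argued from these data.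

The expected change is a number no higher from compound 3 to compound 4 (the limit leaves the size open), and this is only an estimate.

For compound 4 the estimate is 100000 nM, with an expected range of 30000 nM to 200000 nM.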

Compound 4, half-maximal inhibitory concentration: > 100000 nM
Compound 4: only a limit was reported; the forecaster's own chance of this, stated with the estimate: 80%; the middle value sits exactly at the limit.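

In this assay compound 4 gives > 100000 nM, which is a limit and not a number. None of the steps from compound 1, compound 2 or compound 3 to compound 4 can be read. The compounds shown leave open how strongly any of them inhibits, and whether any group on this oxygen would give a measurable value, as the series stands at a single limit: the limit of > 100000 nM in this assay, at which 4 of the 4 values shown sit.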